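Moving the Ring Nitrogen: Expected Cytotoxicity of Compound 4

The source may hold more compounds than are shown below. What is called first, only, known or untested is meant among the compounds shown, and "the series" means these compounds.

Compound 1 `CCOC(=O)c1sc(-c2ccccc2)nc1N1CCC(NCc2ccccc2)CC1`: 11.7%
Compound 2 `CCOC(=O)c1sc(-c2ccccn2)nc1N1CCC(NCc2ccccc2)CC1`: 14.6%
Compound 3 `CCOC(=O)c1sc(-c2ccccn2)nc1N1CCC(NCc2cccc(C(F)(F)F)c2)CC1`: 19.2%

In an ADME assay on RAW264.7 cells (Mus musculus) for cytotoxicity, read by MTT assay, with a stated time of 72 h, tested at 50 uM (a lower number here means less inhibition, a higher number more inhibition at the concentration tested (going by the name of the read-out)), compound 2 gives 14.6%, the second highest of the three numbers shown. The two measured steps are a number 2.9 percentage points higher from compound 1 to compound 2 (within the scatter) and a number 4.6 percentage points higher from compound 2 to compound 3 (within the scatter), both within the scatter. Compound 4 `CCOC(=O)c1sc(-c2ccncc2)nc1N1CCC(NCc2ccccc2)CC1` differs from compound 2 by pyridin-4-yl in place of pyridin-2-yl on an aromatic carbon. Neither measured step moves the nitrogen within this ring, so nothing shown bears directly on the change; the small size of every step so far gives no reason to expect more than the scatter here either. The step of a number 0.4 percentage points higher from compound 2 to compound 4 (within the scatter) is therefore expected to stay within the scatter. Compound 4 is estimated at 15%, with a range from 5% to 28%.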

Compound 4, a percentage reported as inhibition, at one concentration (the size of the read-out at that concentration, not a potency): 10.8%
Estimate against measurement, compound 4: 4.2 percentage points above; the measured number falls inside the stated range.
By their numbers in this assay, from the lowest: compounds 4, 1, 2 and 3 (each within the scatter of the next).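

Moving the ring nitrogen within the ring on this carbon of the shared core gives a number 3.8 percentage points lower from compound 2 to compound 4 (within the scatter) in this assay, so pyridin-4-yl and pyridin-2-yl cannot be told apart here. Replacing phenyl with pyridin-4-yl gives a number 0.9 percentage points lower from compound 1 to compound 4 (within the scatter), which places all three aromatic rings tested at this position within the scatter of one another. No measurement is available that could explain these numbers.

Still open, from the compounds shown here alone, is how pyridin-3-yl would read at this position. Also open, going by these compounds, is whether a group without an aromatic ring, such as a carboxylic acid or an amine, would give a step beyond the scatter.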